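Benzyl in place of 4-hydroxy-3-methylphenyl, still at the limit?

The source may hold more compounds than are shown below. What is called first, only, known or untested is meant among the compounds shown, and "the series" means these compounds.

In a functional assay on SK-HEP1 cells (Homo sapiens) for cytotoxicity, read by MTT assay, with a stated time of 48 h (on this read-out higher numbers stand for weaker inhibition and lower numbers for stronger inhibition), compound 1 `COc1cc2nc(Cl)nc(Nc3cccc(O)c3)c2cc1OC` gives > 40000 nM, which is a limit of the assay and not a number. Compound 2 `COc1cc2nc(Cl)nc(Nc3ccc(O)c(C)c3)c2cc1OC` gives > 40000 nM, again a limit. Among the compounds with values here, the only measured step is a step that the two limits leave unreadable from compound 1 to compound 2, so no size can be carried forward from it. What the series offers so far is the limit of > 40000 nM in this assay, at which 2 of the 2 values shown sit.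

Compound 3 `COc1cc2nc(Cl)nc(NCc3ccccc3)c2cc1OC` carries benzyl in place of 4-hydroxy-3-methylphenyl on a nitrogen on an aromatic ring. With compound 2 resting on > 40000 nM and no readable step available, no direction can be argued, and compound 3 is expected to stay close to that limit. The expected step is a number no higher from compound 2 to compound 3 (the limit leaves the size open), with nothing foreseen beyond the scatter. For compound 3 the estimated value is 40000 nM, with an expected range of 15000 nM to 80000 nM.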

Compound 3, half-maximal inhibitory concentration: 19800 nM
Beside the measured number, compound 3's estimate is 2.0-fold (0.31 log units) above it; low and high end bracket the measured number.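

Within the data shown here, compound 3 is the first compound in this assay with a reading that is a number, which shows that a change on this nitrogen can bring the series into the measurable range. Compounds 1 and 2 give only a limit of the assay: the limit of > 40000 nM in this assay, at which 2 of the 3 values shown sit.

The readable steps are an at least 2.0-fold lower number from compound 2 to compound 3 (0.30 log units; that floor lies within the scatter) and an at least 2.0-fold lower number from compound 1 to compound 3 (0.30 log units; that floor lies within the scatter), so neither change to benzyl is shown to exceed the scatter, while the step between the two limits cannot be read.

The compounds shown do not separate the methylene of benzyl from the loss of the hydroxyl, since both differ at once between the groups compared. Also open, going by these compounds, is how a longer chain such as phenethyl, or a benzyl carrying a hydroxyl or an amine, would read at this nitrogen.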